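A few compounds are considered here, and "the series" means these few. Any claim that something is new, unique, unknown or untested is made for them only; others in the source may bear on it.

Three nucleoside analogues sharing one core have been examined in a functional assay on CEM-DNR-bulk cells (Homo sapiens), read by MTT assay, with a stated time of 72 h (a higher number here means a weaker inhibitor, a lower number a stronger inhibitor), and a fourth now awaits measurement there. Compound 1 `COc1ncnc2c1c(-c1ccoc1)cn2[C@@H]1O[C@H](CO)[C@@H](O)[C@H]1O` carries a methoxy group and a furan-3-yl group; compound 2 `CN(C)c1ncnc2c1c(-c1ccoc1)cn2[C@@H]1O[C@H](CO)[C@@H](O)[C@H]1O` differs from it in bearing a dimethylamino group; compound 3 `CN(C)c1ncnc2c1c(-c1cc3ccccc3o1)cn2[C@@H]1O[C@H](CO)[C@@H](O)[C@H]1O` keeps the dimethylamino group but carries a 1-benzofuran-2-yl group; compound 4 `COc1ncnc2c1c(-c1cc3ccccc3o1)cn2[C@@H]1O[C@H](CO)[C@@H](O)[C@H]1O` combines the methoxy group with the 1-benzofuran-2-yl group.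

In this assay compound 1 reaches only the limit of the assay, > 20000 nM. Compound 2 likewise gives only a limit, > 20000 nM. Compound 3 too gives only a limit, > 20000 nM. Because (the limit of > 20000 nM in this assay, at which 3 of the 3 values shown sit), the step that the two limits leave unreadable from compound 2 to compound 1, made by the change (methoxy in place of dimethylamino on an aromatic carbon), cannot be sized, and the same holds for the step that the two limits leave unreadable from compound 2 to compound 3, made by the change (1-benzofuran-2-yl in place of furan-3-yl on an aromatic carbon).

For the measured compounds named here, the change from compound 3 to compound 4, (methoxy in place of dimethylamino on an aromatic carbon), is the same change as the one from compound 2 to compound 1, set on the same place word for word. Since compound 3 sits at > 20000 nM and the earlier instance of this change could not be sized, the step that the limit leaves unreadable from compound 3 to compound 4 is expected to leave compound 4 at the limit as well. Compound 4 is therefore estimated at 40000 nM, within 15000 nM to 150000 nM.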

Compound 4, half-maximal inhibitory concentration: 10800 nM
Compound 4: middle estimate off by 3.7-fold (0.57 log units), on the high side, and the stated range ends above it.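

On the core carrying 1-benzofuran-2-yl, methoxy in place of dimethylamino gives an at least 1.8-fold lower number from compound 3 to compound 4 (0.26 log units; that floor lies within the scatter) in this assay, and on the methoxy compounds 1-benzofuran-2-yl in place of furan-3-yl gives an at least 1.8-fold lower number from compound 1 to compound 4 (0.26 log units; that floor lies within the scatter); each of these is only a floor, so the true step may be larger, but as printed neither goes beyond the scatter. For the compounds shown here, what the result does show is that this pairing of methoxy with 1-benzofuran-2-yl gives a number rather than a limit, and compound 4 is the only one of the four compounds for which this holds. It does not show that the change carries from one core to the other, as the two instances cannot be compared, and none of the steps among the first three compounds can be read because both ends of each are limits: the limit of > 20000 nM in this assay, at which 3 of the 4 values shown sit.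

The compounds shown leave open how far compound 1, compound 2 and compound 3 lie past their limits, and so how large any of these steps really is. They also leave open whether a smaller amine such as methylamino, or a longer chain such as ethoxy, on that aromatic carbon would give a number alongside the 1-benzofuran-2-yl group.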